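Benzyl ring substitution and growth inhibition of Capan-2 cells

The compounds below may be only part of what the source reports. "The series", "measured", "known", "first", "only" and "open" are said of these compounds alone.

Compound 1, `O=S(=O)(NCCCNCc1cccc2ccccc12)c1cc(C(F)(F)F)cc(C(F)(F)F)c1`: 2700 nM
Compound 2, `O=S(=O)(NCCCCNCc1ccc(Br)cc1)c1cc(C(F)(F)F)cc(C(F)(F)F)c1`: 1900 nM
Compound 3, `O=S(=O)(NCCCNCc1cccc(Cl)c1)c1cc(C(F)(F)F)cc(C(F)(F)F)c1`: 8000 nM

In a functional assay on Capan-2 cells (Homo sapiens) for inhibition, read by MTT assay, with a stated time of 72 h (on this read-out higher numbers stand for weaker inhibition of growth and lower numbers for stronger inhibition of growth), compound 3 gives the highest of the three numbers, so it is the weakest inhibitor of growth among them. Compound 4, `O=S(=O)(NCCCNCc1ccccc1)c1cc(C(F)(F)F)cc(C(F)(F)F)c1`, differs from compound 3 by hydrogen in place of chloro on an aromatic carbon. For the measured compounds named here, two measured steps bear on this change: a 3.0-fold higher number from compound 1 to compound 3 (0.47 log units; beyond the scatter) and a 4.2-fold higher number from compound 2 to compound 3 (0.62 log units; beyond the scatter). Both steps move toward compound 3 and both raise the number beyond the scatter, so taking away the remaining chloro is expected to leave the number where it is or raise it a little further. Compound 4 is therefore expected to show a step of a 1.4-fold higher number from compound 3 to compound 4 (0.14 log units; within the scatter), and its estimated value is 11000 nM, in the range 4500 nM to 27000 nM.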

Compound 4, concentration for 50% growth inhibition: 14000 nM
Compound 4: middle estimate off by 1.3-fold (0.10 log units), on the low side; low and high end bracket the measured number.
By their numbers in this assay, from the lowest: compounds 2 and 1 (each within the scatter of the next); then compounds 3 and 4 (each within the scatter of the next).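

In this assay, hydrogen in place of chloro gives a 1.8-fold higher number from compound 3 to compound 4 (0.24 log units; within the scatter), so chloro and hydrogen at this ring position cannot be told apart here. Phenyl in place of naphthalen-1-yl gives a 5.2-fold higher number from compound 1 to compound 4 (0.71 log units; beyond the scatter), and benzylamino in place of ((4-bromobenzyl)amino)methyl gives a 7.4-fold higher number from compound 2 to compound 4 (0.87 log units; beyond the scatter), so both steps to the bare benzyl compound lie beyond the scatter. No measurement at hand explains these differences. Going by these compounds, whether a methoxy or a nitrile in place of the chloro would move the number beyond the scatter stays open. So does whether the longer chain or the bromo of compound 2 carries its step.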